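The source may report more compounds than this note shows. Statements on the series, on what has been measured and on what is new or still open speak of the compounds shown alone.

Compound 1 `N#Cc1c(F)c(F)c2nc(N)nc(N)c2c1F` is the simplest member of this small set. In a functional assay on SK-OV-3 cells (Homo sapiens) for cytotoxicity, read by MTT assay (a lower number here means a stronger inhibitor, a higher number a weaker inhibitor), compound 1 gives 8 ug/mL. Compound 3 `N#Cc1c(NCc2ccccc2)c(F)c2nc(N)nc(N)c2c1F` differs from it by one change, (benzylamino in place of fluoro on an aromatic carbon), and in this assay compound 3 gives 11 ug/mL, a step of a 1.4-fold higher number from compound 1 to compound 3 (0.14 log units; within the scatter). Compound 2 `N#Cc1c(NCc2ccccc2)c(Cl)c2nc(N)nc(N)c2c1F` carries a different core; how the cores of compound 1 and compound 2 differ is not broken down here. In this assay, for the measured compounds named here, compound 2 gives 0.8 ug/mL, and the single change from it to compound 3 makes a step of a 14-fold higher number from compound 2 to compound 3 (1.14 log units; beyond the scatter).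

Compound 4 `N#Cc1c(NCc2ccccc2)c(Cl)c2nc(N)nc(N)c2c1NCc1ccccc1` has not yet been measured. It arises from compound 2 by benzylamino in place of fluoro on an aromatic carbon. Going by the values given here, this is the same kind of change as the one from compound 1 to compound 3, though the surroundings differ: in compound 1 the carbon in question is ortho to a fluoro group, meta to a fluoro group and para to a fused ring, whereas in compound 2 it is ortho to a fused ring, meta to a benzylamino group and para to a chloro group. Resting on the step of a 1.4-fold higher number from compound 1 to compound 3 (0.14 log units; within the scatter), the step from compound 2 to compound 4 in this assay is expected to be a 1.4-fold higher number from compound 2 to compound 4 (0.14 log units; within the scatter). Compound 4 is therefore estimated at 1.1 ug/mL, expected to fall between 0.4 ug/mL and 3.5 ug/mL.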

Compound 4, half-maximal inhibitory concentration: 3.7 ug/mL
Compound 4: the middle estimate sits 3.4-fold (0.53 log units) below what was measured; measured number outside the range, above it.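

In this assay, benzylamino in place of fluoro on an aromatic carbon does not behave on the core of compound 2 as it does on the core of compound 1, giving a step of a 4.6-fold higher number from compound 2 to compound 4 (0.67 log units; beyond the scatter). Set beside the earlier step, this shows that the size of the step does not carry over unchanged from one core to the other: the same change on two cores in this assay, a 1.4-fold higher number (0.14 log units; within the scatter) from compound 1 to compound 3 and a 4.6-fold higher number (0.67 log units; beyond the scatter) from compound 2 to compound 4, 3.4-fold (0.53 log units) apart, beyond the scatter of two such steps. For the compounds shown here, with only this one pair of steps, it does not show which difference between the cores, or between the surroundings of the carbon that is changed, lies behind the gap, nor whether the gap would hold on any further core.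

The compounds shown have only benzylamino, fluoro and chloro at the places that change, so it remains open how a simple amine such as methylamino, a bromo group or a longer chain such as phenethylamino would behave on either core. Going by these compounds, whether the same gap would appear in other cell lines also remains open.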